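One substituent swap on a compound already at the limit

This account rests on a few compounds, and the source may have more. Where it says the series, first, only, none or still open, it means among the compounds named here.

Measured so far:
Compound 1, `O=C(Nc1nc2ccc(F)cc2s1)N1CCN(c2ccc(Cl)nn2)CC1`, gives > 10000 nM in an assay on HEK293 cells for inhibition of transient receptor potential cation channel subfamily V member 1 (Homo sapiens), read by FLIPR, at pH 5.5 (on this read-out higher numbers stand for weaker inhibition and lower numbers for stronger inhibition), which is a limit of the assay and not a number.
Compound 2, `Cc1ccc(N2CCN(C(=O)Nc3ccc(OC(F)(F)F)cc3)CC2)nn1`, gives > 10000 nM in this assay, again only a limit.

Both readings therefore sit at the limit of > 10000 nM in this assay, at which 2 of the 2 values shown sit. Compound 1 thus stands at the limit, and nothing in these numbers orders it against compound 2, since neither was resolved into a value. Within the data shown here, no step between two measured compounds is available here.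

The change to compound 3, `Cc1ccnnc1N1CCN(C(=O)Nc2nc3ccc(F)cc3s2)CC1`, is 4-methylpyridazin-3-yl in place of 6-chloropyridazin-3-yl on an amine nitrogen in a ring. Compound 1 offers only a limit in this assay, so this change cannot be compared with any measured difference. The step that the limit leaves unreadable from compound 1 to compound 3 is expected to stay within the usual scatter, because the limit of > 10000 nM in this assay, at which 2 of the 2 values shown sit, is where compound 1 already sits and a small swap on the same ring gives no ground to expect a move out of it. Compound 3 is accordingly expected to give about 15000 nM in this assay, with a range from 3000 nM to 60000 nM, most probably reported once more as a limit.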

Compound 3, half-maximal inhibitory concentration: > 25000 nM
Compound 3 was reported as a limit; the forecaster's own chance of this, stated with the estimate: 75%; middle value at least 1.6-fold (0.22 log units) from the limit.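

Going by these compounds, compound 1 and compound 3 are both reported only as limits of the assay and not as numbers, so no step can be read between them, and the size of the change to 4-methylpyridazin-3-yl in place of 6-chloropyridazin-3-yl stays unknown. The compounds shown leave open what change to these structures, if any, would give a resolved value.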